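This account rests on a few compounds, and the source may have more. Where it says the series, first, only, none or still open, it means among the compounds named here.

Compound 1 `CC#C[C@@H](Cc1nnn[nH]1)c1ccc(OCc2ccc3sc(F)c(-c4ccccc4C)c3c2)cc1`: 0.367 h
Compound 2 `CC#C[C@@H](Cc1nnn[nH]1)c1ccc(OCc2ccc3sc(F)c(-c4ccc(OCCOC)cc4C)c3c2)cc1`: 0.35 h
Compound 3 `CC#C[C@@H](Cc1nnn[nH]1)c1ccc(OCc2ccc3sc(C#N)c(-c4ccccc4C)c3c2)cc1`: 0.533 h

These three numbers come from an ADME assay on microsomes from liver (Rattus norvegicus) for metabolic stability; on this read-out lower numbers stand for a shorter-lived compound and higher numbers for a longer-lived compound. Compound 3, at 0.533 h, lies within the usual scatter of both compound 1 and compound 2, so the numbers do not set it apart from either.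

The next compound to consider is compound 4 `CC#C[C@@H](Cc1nnn[nH]1)c1ccc(OCc2ccc3sc(Cl)c(-c4ccccc4C)c3c2)cc1`, which matches compound 3 except for one group: chloro in place of cyano on an aromatic carbon. Put simply, this is chloro in place of cyano on an aromatic carbon.

The most relevant evidence is a change at this same carbon, cyano in place of fluoro. It gave a 1.5-fold higher number from compound 1 to compound 3 (0.16 log units; within the scatter), so swapping these two groups made no clear difference. The other measured change, 2-methoxyethoxy in place of hydrogen on an aromatic carbon, gave a 1.0-fold lower number from compound 1 to compound 2 (0.02 log units; within the scatter), but it concerns a different part of the molecule and says little here. For the measured compounds named here, no measured compound carries chloro, so this evidence is only indirect.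

Going by the values given here, with the one step at this carbon inside the scatter, no step beyond the scatter is expected in this assay. The estimated change is a 1.2-fold lower number from compound 3 to compound 4 (0.09 log units; within the scatter). Compound 4 is expected at 0.43 h, with an estimated range of 0.25 h to 0.75 h.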

Compound 4, half-life: 1.08 h
The estimate for compound 4 lay 2.5-fold (0.40 log units) below the measured number; measured number outside the range, above it.
By their numbers in this assay, from the lowest: compounds 2, 1 and 3 (each within the scatter of the next); then compound 4.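

The carbon next to the ring sulfur turns out to be a position where the group can matter in this assay: chloro gives a 2.0-fold higher number from compound 3 to compound 4 (0.31 log units; beyond the scatter), and a 2.9-fold higher number from compound 1 to compound 4 (0.47 log units; beyond the scatter), so both steps lie beyond the scatter. For the compounds shown here, the earlier swap at this carbon, a 1.5-fold higher number from compound 1 to compound 3 (0.16 log units; within the scatter), stayed within the scatter and could have suggested that the group here hardly counts, but that holds only for fluoro and cyano, and chloro is the one group of the three that stands apart. Nothing measured on these compounds accounts for the difference between chloro and the other two groups.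

The compounds shown leave open whether this longer half-life belongs to chloro alone or would also appear with bromo, a methyl group or an amine on the same carbon. They also leave open whether chloro would give a similar step on compound 2, which carries the 2-methoxyethoxy group on the 2-methylphenyl ring, or whether the step holds only for the simpler ring of compound 1.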